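Replacing a Nitrile Aryl with Tolyl: Cytotoxicity Outlook

This account rests on a few compounds, and the source may have more. Where it says the series, first, only, none or still open, it means among the compounds named here.

Measured compounds:
compound 1 `CC1(c2ccc(-c3ccccc3C#N)cc2)CC(S(=O)(=O)c2ccc(F)cc2)=C(c2ccc(/C(N)=N\O)cc2)O1` — 58300 nM
compound 2 `CC1(Cc2ccccc2)CC(S(=O)(=O)c2ccc(F)cc2F)=C(c2ccc(/C(N)=N\O)cc2)O1` — 90600 nM

In an ADME assay on HepG2 cells (Homo sapiens) for cytotoxicity, read by MTT assay, with a stated time of 72 h (on this read-out higher numbers stand for lower toxicity in this test and lower numbers for higher toxicity in this test), compound 1 gives 58300 nM, and compound 2 gives 90600 nM; the two numbers lie within the scatter of each other, so neither stands apart. Compound 3 `Cc1ccc(-c2ccc(C3(C)CC(S(=O)(=O)c4ccc(F)cc4)=C(c4ccc(/C(N)=N\O)cc4)O3)cc2)cc1` differs from compound 1 by 4-methylphenyl in place of 2-cyanophenyl on an aromatic carbon. Going by the values given here, no measured pair shows this step, so the expectation for compound 3 is a step of a 1.2-fold lower number from compound 1 to compound 3 (0.07 log units; within the scatter) that stays within the scatter, in no firm direction. Compound 3 is therefore estimated at 50000 nM, in the range 20000 nM to 120000 nM.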

Compound 3, half-maximal cytotoxic concentration: 13700 nM
For compound 3 the middle estimate is 3.6-fold (0.56 log units) above the measured one, and the stated range ends above it.
By their numbers in this assay, from the lowest: compound 3; then compounds 1 and 2 (each within the scatter of the next).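

In this assay, the group on this aromatic carbon, para to a large group, turns out to matter: 4-methylphenyl in place of 2-cyanophenyl gives a 4.3-fold lower number from compound 1 to compound 3 (0.63 log units; beyond the scatter), a modest step. The earlier compounds shown here differed in more than one place and could not show this for a single change. Nothing on hand bears on why the step arises. Going by these compounds, it remains open which part of the exchange carries the step, the loss of the nitrile or the gain of the methyl. On these data alone, it is also open whether a plain phenyl or a phenyl carrying an amine would sit nearer compound 1 or compound 3.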